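This account rests on a few compounds, and the source may have more. Where it says the series, first, only, none or still open, it means among the compounds named here.

In a functional assay on NCI-H1650 cells (Homo sapiens) for cytotoxicity, read by MTT assay, with a stated time of 48 h (on this read-out lower numbers stand for stronger inhibition and higher numbers for weaker inhibition), the three measured compounds gave the following numbers:

Compound 1, `CCOc1ccc2c(Cl)ccnc2c1`: 3340 nM
Compound 2, `Fc1ccc(COc2ccc3c(Cl)ccnc3c2)cc1`: 2230 nM
Compound 3, `CCCCOc1ccc2c(Cl)ccnc2c1`: 2570 nM

Compound 3 stands second highest of the three numbers. Its nearest neighbour is compound 2, and its furthest is compound 1; both gaps are within the scatter, so on these numbers the three compounds cannot be ranked. Within the data shown here, the only step among the measured compounds, a 1.3-fold lower number from compound 1 to compound 3 (0.11 log units; within the scatter), lengthens the chain on the ether oxygen and changes nothing beyond the scatter.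

Compound 4, `Clc1ccnc2cc(OCc3ccccc3)ccc12`, has not yet been measured in this assay. It differs from compound 3 by phenyl in place of propyl on a saturated chain carbon bound to an oxygen on an aromatic ring. Among the measured compounds shown here, no measured step bears directly on this exchange of a propyl for a phenyl. The closest point of comparison is compound 2, which also carries a ring on the saturated chain carbon bound to the ether oxygen and gives a number within the scatter of compound 3. Since neither the chain extension nor the ring-bearing compound 2 moved the number beyond the scatter, compound 4 is expected to show no step beyond the scatter, a 1.1-fold lower number from compound 3 to compound 4 (0.03 log units; within the scatter). Compound 4 is therefore estimated at 2400 nM, within a range of 1200 nM to 4800 nM.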

Compound 4, half-maximal inhibitory concentration: 2720 nM
For compound 4 the middle estimate is 1.1-fold (0.05 log units) below the measured one; the measured number falls inside the stated range.
By their numbers in this assay, from the lowest: compounds 2, 3, 4 and 1 (each within the scatter of the next).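

In this assay the exchange of propyl for phenyl on a saturated chain carbon bound to an oxygen on an aromatic ring gives a 1.1-fold higher number from compound 3 to compound 4 (0.02 log units; within the scatter), so at this place a six-membered aromatic ring of carbon only and an open chain cannot be told apart by their numbers. The same holds for the exchange of methyl for phenyl, with a 1.2-fold lower number from compound 1 to compound 4 (0.09 log units; within the scatter), and the hydrogen in place of fluoro on an aromatic carbon gives a 1.2-fold higher number from compound 2 to compound 4 (0.09 log units; within the scatter), so the fluoro group of the earlier ring-bearing compound makes no difference beyond the scatter. Nothing available explains why these exchanges leave the number within the scatter.

From the compounds shown here alone, it remains open whether an amine or a carboxylic acid at this place, or a nitrile or methoxy group on the phenyl ring in place of the fluoro, would move the number beyond the scatter. All four compounds share one core, so the compounds shown also leave open what an amine in place of the chloro group on that core would do in this assay and whether the flat picture at the ether oxygen would then persist.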